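Replacing butylamino with cyclopentyl on a shared core

This account rests on a few compounds, and the source may have more. Where it says the series, first, only, none or still open, it means among the compounds named here.

Measured in an ADME assay on Vero cells (Chlorocebus sabaeus) for cytotoxicity; on this read-out higher numbers stand for lower toxicity in this test and lower numbers for higher toxicity in this test:
Compound 1 `c1cc(NC2CCCC2)c2nc(-c3ccc(OCC4CC4)cc3)c(-c3ccnc(NC4CCCC4)n3)n2c1`: > 40000 nM
Compound 2 `CCCCNc1cccn2c(-c3ccnc(NC4CCCC4)n3)c(-c3ccc(F)cc3)nc12`: 32000 nM

Compound 1 gives only a limit of the assay, > 40000 nM, and not a true number. For the measured compounds named here, that leaves compound 2, at 32000 nM, with the only actual number so far, so there is no series of numbers against which to rank it.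

Compound 3 `Fc1ccc(-c2nc3c(C4CCCC4)cccn3c2-c2ccnc(NC3CCCC3)n2)cc1` keeps the core of compound 2 but has cyclopentyl in place of butylamino on an aromatic carbon. Going by the values given here, no measured pair shows what this exchange does. In this assay, the expectation is therefore a small move toward lower numbers, possibly none beyond the usual scatter. The estimated step of a 1.3-fold lower number from compound 2 to compound 3 (0.11 log units; within the scatter) is modest. For compound 3 the expected value is 25000 nM, with an estimated range of 10000 nM to 40000 nM.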

Compound 3, half-maximal cytotoxic concentration: > 40000 nM
Compound 3 gave a limit, no number (the forecaster's own chance of this, stated with the estimate: 30%); middle value at least 1.6-fold (0.20 log units) from the limit.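

Putting cyclopentyl in place of butylamino on an aromatic carbon gives an at least 1.2-fold higher number from compound 2 to compound 3 (0.09 log units; that floor lies within the scatter) in this assay. For the compounds shown here, this is the first look at this position, and it shows that the number does not fall within the range the test can read when the nitrogen of butylamino, with its hydrogen-bond donor and acceptor, gives way to an all-carbon ring. For compound 3 the reading is a limit of the assay and not a number, and the top of the test's range caps what can be seen: the limit of > 40000 nM in this assay, at which 2 of the 3 values shown sit.

The compounds shown do not separate the loss of the nitrogen from the gain of the ring. A pentyl chain, with no nitrogen and no ring, or a piperidine, with both, would tell these two apart.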